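Amide aryl swap on a shared core: from dimethoxy to methylsulfanyl

The source may hold more compounds than are shown below. What is called first, only, known or untested is meant among the compounds shown, and "the series" means these compounds.

Measured compounds:
Compound 1 `O=C(c1cccc(/C=C2\CC(=O)N(c3ccccc3)C2=O)c1)N1CCCC1`: > 100000 nM
Compound 2 `COc1ccc(OC)c(NC(=O)c2cccc(/C=C3\CC(=O)N(c4ccccc4)C3=O)c2)c1`: > 100000 nM

Both values come from an ADME assay on SW480 cells (Homo sapiens) for cytotoxicity, read by MTT assay, with a stated time of 72 h (a higher number here means a weaker inhibitor, a lower number a stronger inhibitor), which measures how strongly a compound stops the growth of a colon cancer cell line. In this assay compound 1 gives > 100000 nM, which is a limit of the assay and not a number. Compound 2 gives > 100000 nM in this assay, again a limit rather than a number. The step that the two limits leave unreadable from compound 1 to compound 2 therefore cannot be read, and compound 2 stands only at that limit, as the limit of > 100000 nM in this assay, at which 2 of the 2 values shown sit, records for both values shown.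

Compound 3 `CSc1cccc(NC(=O)c2cccc(/C=C3\CC(=O)N(c4ccccc4)C3=O)c2)c1` changes (3-(methylsulfanyl)phenyl in place of 2,5-dimethoxyphenyl on an amide-type nitrogen). Among the compounds with values here, no measured step bears on this change, since the one step available is unreadable. The expectation for compound 3 is therefore that it stays at the limit, with an estimated step that the limit leaves unreadable from compound 2 to compound 3. Compound 3 is estimated at 150000 nM, with a range from 40000 nM to 600000 nM.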

Compound 3, half-maximal inhibitory concentration: 74300 nM
The estimate for compound 3 lay 2.0-fold (0.31 log units) above the measured number; the measured number falls inside the stated range.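

Within the data shown here, with the 3-(methylsulfanyl)phenyl group on the amide-type nitrogen, compound 3 gives the first actual number in this assay, so this position can now be read on a scale rather than only at a limit. The smallest step that the values allow is an at least 1.3-fold lower number from compound 2 to compound 3 (0.12 log units; that floor lies within the scatter), and against the pyrrolidine amide it is an at least 1.3-fold lower number from compound 1 to compound 3 (0.12 log units; that floor lies within the scatter), so neither floor alone shows a change beyond ordinary assay scatter. Compound 1 and compound 2 remain at a limit of the assay, not a number: the limit of > 100000 nM in this assay, at which 2 of the 3 values shown sit.

As far as these compounds go, the true size of both steps stays unknown, as does whether the sulfur atom or the place of the group on the ring matters. Also open, from the compounds shown here alone, is how the number would respond to an amine or a carboxylic acid on that phenyl ring.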